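The compounds below may be only part of what the source reports. "The series", "measured", "known", "first", "only" and "open" are said of these compounds alone.

Compound 3 `COC(=O)c1cc(-c2cccc(NC(=O)c3ccc(/C=C/C(=O)c4ccccc4O)cc3)c2)on1` carries a 2-((2-hydroxyphenyl)carbonyl)ethenyl group on the shared core, and in an ADME assay on Vero cells (Chlorocebus sabaeus) for cytotoxicity, read by MTT assay, with a stated time of 72 h (on this read-out lower numbers stand for higher toxicity in this test and higher numbers for lower toxicity in this test), compound 3 gives "not determined" (no result reported), so no number stands for it on this read-out. Two neighbours of compound 3 were measured. Compound 1 `COC(=O)c1cc(-c2cccc(NC(=O)c3ccc(C4OC4C(=O)c4ccc(Cl)cc4)cc3)c2)on1` gives in this assay a value that is a limit, > 20 ug/mL. Compound 2 `COC(=O)c1cc(-c2cccc(NC(=O)c3ccc(/C=C/C(=O)c4ccc(Br)cc4)cc3)c2)on1` likewise gives a limit in this assay, > 20 ug/mL. Among the compounds with values here, the one step between measured compounds that differ in a single place, a step that the two limits leave unreadable from compound 1 to compound 2, cannot be sized because both its ends sit at the limit of > 20 ug/mL in this assay, at which 2 of the 3 values shown sit. Compound 4 `COC(=O)c1cc(-c2cccc(NC(=O)c3ccc(/C=C/C(=O)c4ccc(Cl)cc4Cl)cc3)c2)on1` differs from compound 3 by 2,4-dichlorophenyl in place of 2-hydroxyphenyl on a carbonyl carbon, placed on a carbonyl carbon whose other neighbour is a double-bonded chain carbon. Within the data shown here, no measured step shares this change, and the only readable fact is that both measured compounds rest at the limit. Compound 4 is therefore expected to give about 20 ug/mL in this assay, estimated between 10 ug/mL and 40 ug/mL, most probably reported once more as a limit rather than a number.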

Compound 4, half-maximal cytotoxic concentration: > 40 ug/mL
Compound 4: only a limit was reported (the forecaster's own chance of this, stated with the estimate: 70%); middle value at least 2.0-fold (0.30 log units) away from the limit.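

In this assay, compound 1, compound 2 and compound 4 all give only limits, so the steps from compound 2 to compound 4 and from compound 1 to compound 4 cannot be read. What the compounds shown leave open is whether swapping 2-hydroxyphenyl for 2,4-dichlorophenyl changes the read-out at all.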